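Methyl on the fused core: from compound 3 to compound 4

This account rests on a few compounds, and the source may have more. Where it says the series, first, only, none or still open, it means among the compounds named here.

Measured compounds:
compound 1 `Cc1ccn2c(C(=O)c3sc(N)nc3-c3ccccc3)cnc2c1` — 26%
compound 2 `Cc1ccn2c(C(=O)c3sc(N)nc3C)cnc2c1` — 66%
compound 3 `Nc1ncc(C(=O)c2cnc3ccccn23)s1` — 33%

In a functional assay on the whole organism (strain Sprague-Dawley) for inhibition, with Rattus norvegicus as the target, read by paw edema, with stated times of 1 h and 3 h, at a dose of 50 mg/kg by the oral route (a lower number here means less inhibition, a higher number more inhibition at the dose given (going by the name of the read-out)), compound 3 stands second highest of the three numbers. Its nearest neighbour is compound 1, whose value lies within the scatter of that of compound 3, so no order between the two can be claimed. Compound 2 stands well beyond the scatter above compound 3.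

Among the compounds with values here, the one step between measured compounds that differ in one place is a number 40 percentage points higher from compound 1 to compound 2 (beyond the scatter), a change on the aminothiazole part of the shared core.

Compound 4 `Cc1ccn2c(C(=O)c3cnc(N)s3)cnc2c1` is not yet measured. It differs from compound 3 by methyl in place of hydrogen on an aromatic carbon. Within the data shown here, this change sits on the six-membered aromatic ring with one nitrogen of the fused core, not on the aminothiazole where the measured step took place; no measured step touches this position, so the step from compound 1 to compound 2 bears on it only in that a methyl elsewhere moved the number. Compound 4 also shares the methyl of compound 1 and compound 2 on this ring, but each of those pairs differs from compound 4 in a further place, so their values give no clean guide.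

For compound 4 the expected step is a number 7 percentage points higher from compound 3 to compound 4 (within the scatter), that is none beyond the scatter. Compound 4 is estimated at 40%, with a range from 20% to 62%.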

Compound 4, a percentage reported as inhibition, in the whole organism at one dose (the size of the read-out at that dose, not a potency): 77%
Estimate against measurement, compound 4: 37 percentage points below; measured number above the stated range.
By their numbers in this assay, from the lowest: compounds 1 and 3 (each within the scatter of the next); then compound 2; then compound 4.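

In this assay, within the data shown here, methyl in place of hydrogen on an aromatic carbon of the six-membered aromatic ring with 1 nitrogen, opposite the ring nitrogen, gives a number 44 percentage points higher from compound 3 to compound 4 (beyond the scatter) and shows that this position, which no earlier step touched, can carry a large step on the entry of a single carbon. With this methyl in place, the other varied aromatic carbon of the shared core can now be read against hydrogen: the modest step of a number 11 percentage points higher from compound 2 to compound 4 (beyond the scatter) and the large step of a number 51 percentage points higher from compound 1 to compound 4 (beyond the scatter) put hydrogen above methyl and methyl above phenyl in these three compounds, so the best of them combines the new methyl with an unsubstituted carbon at that other place. Nothing at hand explains either the gain from the methyl or this order of hydrogen, methyl and phenyl.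

Going by these compounds, it remains open whether an ethyl group, a methoxy group or a chlorine atom on the same carbon would match the methyl, and whether a methyl elsewhere on that ring would do the same. On these data alone, these are readings at a single dose, so how the compounds compare in potency also remains open.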